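Sulfonyl aryl variation in the B1 antagonist series

This account rests on a few compounds, and the source may have more. Where it says the series, first, only, none or still open, it means among the compounds named here.

Compound 1 `CC(C)(C)NCc1ccc2c(c1)CCC[C@H]2NC(=O)C[C@@H]1CCCCN1S(=O)(=O)c1ccccc1` — 2400 nM
Compound 2 `CCCCOc1ccc(S(=O)(=O)N2CCCC[C@H]2CC(=O)N[C@@H]2CCCc3cc(CNC(C)(C)C)ccc32)cc1` — 590 nM
Compound 3 `Cc1ccc(S(=O)(=O)N2CCCC[C@H]2CC(=O)N[C@@H]2CCCc3cc(CNC(C)(C)C)ccc32)cc1Cl` — 22 nM

Three compounds share one core and differ only in the aryl group on the sulfonyl sulfur. In a functional assay for inhibition of B1 bradykinin receptor (Homo sapiens), read by calcium flux (on this read-out lower numbers stand for stronger inhibition and higher numbers for weaker inhibition), compound 3 gives the lowest number of the three: a 110-fold lower number from compound 1 to compound 3 (2.04 log units; beyond the scatter) and a 27-fold lower number from compound 2 to compound 3 (1.43 log units; beyond the scatter), both beyond the scatter, whereas the change a 4.1-fold lower number from compound 1 to compound 2 (0.61 log units; beyond the scatter) was modest. Compound 4 `Cc1ccc(S(=O)(=O)N2CCCC[C@H]2CC(=O)N[C@@H]2CCCc3cc(CNC(C)(C)C)ccc32)cc1C(F)(F)F` follows from compound 3 by trifluoromethyl in place of chloro on an aromatic carbon. Within the data shown here, no measured step covers this exact exchange; the two large steps show that the substitution pattern of this ring matters, but both start from compound 3 and cannot tell which way a change there runs. The expectation is therefore a small step, within or near the scatter, around a 1.4-fold higher number from compound 3 to compound 4 (0.13 log units; within the scatter). For compound 4 the expected result in this assay is 30 nM with a range of 10 nM to 100 nM.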

Compound 4, half-maximal inhibitory concentration: 16 nM
Compound 4: the middle estimate sits 1.9-fold (0.27 log units) above what was measured; measured number inside the range.
By their numbers in this assay, from the lowest: compounds 4 and 3 (each within the scatter of the next); then compound 2; then compound 1.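

In this assay, trifluoromethyl, with 4 heavy atoms, stands in for chloro, with 1, ortho to the methyl group, and the step stays within the scatter: a 1.4-fold lower number from compound 3 to compound 4 (0.14 log units; within the scatter). The 4-methyl-3-(trifluoromethyl)phenyl group also keeps large steps from the other two aryl groups: a 37-fold lower number from compound 2 to compound 4 (1.57 log units; beyond the scatter) and a 150-fold lower number from compound 1 to compound 4 (2.18 log units; beyond the scatter). Nothing available here accounts for these results.

On these data alone, whether the methyl group contributes alongside chloro or trifluoromethyl remains open. So does the outcome of a nitrile, a methoxy group or an amine at this position.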